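The compounds below may be only part of what the source reports. "The series", "measured", "known", "first", "only" and "open" are said of these compounds alone.

Measured in a functional assay on SMMC-7721 cells (Homo sapiens) for inhibition, read by MTT assay, with a stated time of 48 h; on this read-out higher numbers stand for weaker inhibition and lower numbers for stronger inhibition:
compound 1 `Cc1ccc(NC(=O)Nc2cccc(-c3cccc4[nH]nc(N)c34)c2)cc1Cl`: 510 nM
compound 2 `Nc1n[nH]c2cccc(-c3cccc(NC(=O)Nc4cccc(F)c4)c3)c12`: 1240 nM
compound 3 `Nc1n[nH]c2cccc(-c3cccc(NC(=O)Nc4cccc(Cl)c4)c3)c12`: 1830 nM

Compound 1 holds the lowest number of the three, and its steps to the other two both lie beyond the scatter. The next compound, compound 4 `COc1cccc(NC(=O)Nc2cccc(-c3cccc4[nH]nc(N)c34)c2)c1`, has not yet been measured. Its change from compound 1 is 3-methoxyphenyl in place of 3-chloro-4-methylphenyl on an amide-type nitrogen. Two measured steps also give up the 3-chloro-4-methylphenyl group: a 2.4-fold higher number from compound 1 to compound 2 (0.39 log units; beyond the scatter) and a 3.6-fold higher number from compound 1 to compound 3 (0.55 log units; beyond the scatter). Both are modest and point the same way. The step that separates them, a 1.5-fold higher number from compound 2 to compound 3 (0.17 log units; within the scatter), is within the scatter. Within the data shown here, no compound with the 3-methoxyphenyl group has a measured value, so this comparison is the only guide. A modest rise of similar size is therefore expected in this assay. The expected step is a 2.7-fold higher number from compound 1 to compound 4 (0.44 log units; beyond the scatter). Compound 4 is estimated at 1400 nM, with an expected range from 600 nM to 3200 nM.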

Compound 4, half-maximal inhibitory concentration: 2860 nM
Estimate against measurement, compound 4: 2.0-fold (0.31 log units) below, and the stated range covers the measured number.
By their numbers in this assay, from the lowest: compound 1; then compounds 2, 3 and 4 (each within the scatter of the next, the first and the last beyond it).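

In this assay, moving from the 3-chloro-4-methylphenyl group on the amide-type nitrogen to the 3-methoxyphenyl group gives a 5.6-fold higher number from compound 1 to compound 4 (0.75 log units; beyond the scatter) and so adds a third replacement that raises the number, with none among the four compounds going against this. The new compound also sharpens the comparison among the three replacements: methoxy in place of chloro gives a 1.6-fold higher number from compound 3 to compound 4 (0.19 log units; within the scatter) while methoxy in place of fluoro gives a 2.3-fold higher number from compound 2 to compound 4 (0.36 log units; beyond the scatter) so that only the fluoro and methoxy compounds stand apart. Compound 1 therefore remains separate from all three replacements.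

Still open, going by these compounds, is whether a methyl group alone on this ring, without the chloro, would keep the number of compound 1, and how an amine or a carboxylic acid there would fare. Nothing available explains these steps.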